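Phenyl for Propyl on the Carbamate Oxygen

This account rests on a few compounds, and the source may have more. Where it says the series, first, only, none or still open, it means among the compounds named here.

Three carbamates sharing a selenocyanate-bearing core have been measured in an ADME assay on 184B5 cells (Homo sapiens) for cytotoxicity, read by MTT assay, with a stated time of 72 h; a higher number here means a weaker inhibitor of growth, a lower number a stronger inhibitor of growth. Compound 1 `N#C[Se]c1ccc(NC(=O)Oc2ccc(F)cc2)cc1` gives 6900 nM. Compound 2 `CCCOC(=O)Nc1ccc([Se]C#N)cc1` gives 3700 nM, and compound 3 `N#C[Se]c1ccc(NC(=O)OCc2ccccc2)cc1` gives 5000 nM. Compound 2 has the lowest of the three numbers, but its nearest neighbour, compound 3, and its furthest, compound 1, both sit within the scatter of it, so no order among the three can be claimed.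

Compound 4 `N#C[Se]c1ccc(NC(=O)Oc2ccccc2)cc1` has not yet been measured. It differs from compound 2 in one place: phenyl in place of propyl on an oxygen next to a carbonyl group.

For the measured compounds named here, the one measured step that bears on this change also puts a phenyl where a saturated chain stood, though on a chain carbon rather than directly on the oxygen next to a carbonyl group: a 1.4-fold higher number from compound 2 to compound 3 (0.13 log units; within the scatter). Compound 1, which likewise carries a six-membered aromatic ring on an oxygen next to a carbonyl group, gives a number close to that of compound 2. Neither comparison shows movement beyond the scatter, so compound 4 is expected to stay close to compound 2. The expected step is a 1.5-fold higher number from compound 2 to compound 4 (0.17 log units; within the scatter), no larger than the scatter. Compound 4 is therefore estimated at 5500 nM, within a range of 2500 nM to 12000 nM.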

Compound 4, concentration for 50% growth inhibition: 400 nM
Estimate against measurement, compound 4: 14-fold (1.14 log units) above; measured number outside the range, below it.
By their numbers in this assay, from the lowest: compound 4; then compounds 2, 3 and 1 (each within the scatter of the next).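

In this assay, the oxygen next to a carbonyl group proves sensitive to what it carries: phenyl in place of propyl there gives a 9.3-fold lower number from compound 2 to compound 4 (0.97 log units; beyond the scatter), whereas phenyl on a saturated chain carbon gave only a 1.4-fold higher number from compound 2 to compound 3 (0.13 log units; within the scatter). The ring itself is sensitive as well, for the change of a single atom, hydrogen in place of fluoro on an aromatic carbon, gives a 17-fold lower number from compound 1 to compound 4 (1.24 log units; beyond the scatter), so the low number of compound 4 belongs to the unsubstituted phenyl and not to any six-membered aromatic ring at this place. Nothing shown here accounts for either step.

The compounds shown leave open whether any group other than hydrogen on that phenyl ring, such as chloro, methyl or methoxy, would keep a number as low as that of compound 4, since fluoro is the only substituent on the ring to be compared. Also open, on these data alone, is how another ring on the same oxygen, such as pyridine or naphthyl, would compare with phenyl.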